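The source may hold more compounds than are shown below. What is called first, only, known or untested is meant among the compounds shown, and "the series" means these compounds.

Compound 1 `O=C(Nc1cccc(-n2cc(-c3ccncc3)c(-c3cc(O)cc(Cl)c3)n2)c1)Nc1ccc(Cl)c(Cl)c1` and compound 2 `COc1cc(Cl)cc(-c2nn(-c3cccc(NC(=O)Nc4ccc(Cl)c(Cl)c4)c3)cc2-c2ccncc2)c1` share a core and differ by one change: methyl in place of hydrogen on an oxygen on an aromatic ring. In a functional assay on Malme-3M cells (Homo sapiens) for inhibition, read by sulforhodamine B assay, with a stated time of 48 h, tested at 10 uM (on this read-out higher numbers stand for a weaker effect at the one concentration tested and lower numbers for a stronger effect), compound 1 gives -35.1%, and compound 2 gives -19.8%, a step of a number 15.3 percentage points higher from compound 1 to compound 2 (beyond the scatter). Compound 3 `O=C(Nc1cccc(-n2cc(-c3ccncc3)c(-c3cc(O)cc(Cl)c3)n2)c1)c1cc(C(F)(F)F)cc(C(F)(F)F)c1` carries a different core; how its core differs from that of compound 1 is not broken down here. Compound 3 gives 61.8% in this assay, the highest of the three numbers. Compound 4 `COc1cc(Cl)cc(-c2nn(-c3cccc(NC(=O)c4cc(C(F)(F)F)cc(C(F)(F)F)c4)c3)cc2-c2ccncc2)c1` is made from compound 3 by the same change: methyl in place of hydrogen on an oxygen on an aromatic ring, at a place described in the same words. Because the step of a number 15.3 percentage points higher from compound 1 to compound 2 (beyond the scatter) was modest, a modest step is expected again, a number 10.2 percentage points higher from compound 3 to compound 4 (beyond the scatter). Compound 4 is therefore estimated to give 72% in this assay, between 50% and 92%.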

Compound 4, a percentage reported as activity, at one concentration (the size of the read-out at that concentration, not a potency): 104%
Beside the measured number, compound 4's estimate is 32 percentage points below it, outside the stated range (above it).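

Replacing hydroxy with methoxy on the 3-chloro-5-hydroxyphenyl group gives a number 42.2 percentage points higher from compound 3 to compound 4 (beyond the scatter) in this assay, so the number rises on this core as it did on the core of compound 1. The direction is shared by these two pairs, but the size of the step does not carry over from one core to the other: the same change on two cores in this assay, a number 15.3 percentage points higher (beyond the scatter) from compound 1 to compound 2 and a number 42.2 percentage points higher (beyond the scatter) from compound 3 to compound 4, 26.9 percentage points apart, beyond the scatter of two such steps. Two pairs cannot show why the sizes differ, nor how the change would behave on a third core.

From the compounds shown here alone, whether a longer chain such as ethyl on this oxygen would move the number in the same way stays open. The same holds for an amine in place of the hydroxy group.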